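The source may report more compounds than this note shows. Statements on the series, on what has been measured and on what is new or still open speak of the compounds shown alone.

Measured compounds:
compound 1, `COc1cc(-c2nn(-c3cccc(NC(=O)Nc4ccc(Cl)c(Cl)c4)c3)cc2-c2ccncc2)ccc1Cl`, 741 nM
compound 2, `O=C(Nc1cccc(-n2cc(-c3ccncc3)c(-c3ccc(Cl)c(O)c3)n2)c1)Nc1ccc(Cl)c(Cl)c1`, 570 nM

In a functional assay on SK-MEL-5 cells (Homo sapiens) for inhibition, read by sulforhodamine B assay, with a stated time of 48 h (a lower number here means a stronger inhibitor of growth, a higher number a weaker inhibitor of growth), compound 2 gives 570 nM, the lower of the two numbers, while compound 1 gives 741 nM; the step of a 1.3-fold lower number from compound 1 to compound 2 (0.11 log units; within the scatter) lies within the scatter, so the two compounds cannot be told apart on these data.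

Compound 3, `O=C(Nc1cccc(-n2cc(-c3ccncc3)c(-c3ccc(Cl)c(O)c3)n2)c1)Nc1ccc(Cl)c(C(F)(F)F)c1`, has not yet been measured. It differs from compound 2 by trifluoromethyl in place of chloro on an aromatic carbon. Going by the values given here, the only measured step, a 1.3-fold lower number from compound 1 to compound 2 (0.11 log units; within the scatter), concerns a different ring of the shared core and was itself within the scatter; no measured step touches the ring where this change sits. With nothing pointing in either direction, the step is expected to be a 1.0-fold lower number from compound 2 to compound 3 (0.02 log units; within the scatter), that is, no change beyond the scatter. Compound 3 is therefore estimated at 550 nM, with a range from 200 nM to 1500 nM.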

Compound 3, concentration for 50% growth inhibition: 550 nM
Estimate against measurement, compound 3: no gap at the digits printed; the measured number falls inside the stated range.
By their numbers in this assay, from the lowest: compounds 3, 2 and 1 (each within the scatter of the next).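

In this assay, placing trifluoromethyl where chloro stood on the 3,4-dichlorophenyl ring gives a 1.0-fold lower number from compound 2 to compound 3 (0.02 log units; within the scatter), so compound 2 and compound 3 cannot be told apart. This is the only pair shown that alters this ring, and it shows that a group of four heavy atoms can replace one of a single heavy atom at this place with no change beyond the scatter. No measurement shown bears on what lies behind this result.

As far as these compounds go, whether an amine, a carboxylic acid or a longer chain at this place would also leave growth inhibition unchanged remains open. Also open, from the compounds shown here alone, is what would happen if the remaining chloro on this ring were replaced, since compound 2 and compound 3 both keep it.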